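From a pentyl chain to a sulfur-bearing ring

A few compounds are considered here, and "the series" means these few. Any claim that something is new, unique, unknown or untested is made for them only; others in the source may bear on it.

Measured compounds:
compound 1 `O=c1cc(Cn2cc(CCCO)nn2)c2ccc(O)cc2o1`: > 100000 nM
compound 2 `CCCCCCc1cn(Cc2cc(=O)oc3cc(O)ccc23)nn1`: > 100000 nM

Both measured compounds share one core. In a functional assay on SW-620 cells (Homo sapiens) for inhibition, read by MTT assay, with a stated time of 72 h (on this read-out higher numbers stand for weaker inhibition and lower numbers for stronger inhibition), compound 1 gives > 100000 nM, which is a limit of the assay and not a number. In this assay compound 2 gives > 100000 nM, likewise only a limit. Within the data shown here, the single measured step, a step that the two limits leave unreadable from compound 1 to compound 2, is therefore unreadable, and the limit of > 100000 nM in this assay, at which 2 of the 2 values shown sit, is all that the measured compounds show.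

Compound 3 `O=c1cc(Cn2cc(CSC(=S)N3CCNCC3)nn2)c2ccc(O)cc2o1` differs from compound 2 by a group of 9 heavy atoms (5 carbon, 2 nitrogen, 2 sulfur; one six-membered non-aromatic ring with 2 hetero atoms) in place of a group of 5 heavy atoms (5 carbon; no ring), on a saturated chain carbon bound to an aromatic carbon. Among the measured compounds shown here, no measured step bears on this change, so neither a size nor a direction beyond the scatter can be drawn from the data.

Compound 3 is therefore expected to sit near 100000 nM, with an estimated range from 30000 nM to 300000 nM, and most probably to be reported again only as a limit. The step of a number no higher from compound 2 to compound 3 (the limit leaves the size open) that this estimate means is expected to lie within the scatter.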

Compound 3, half-maximal inhibitory concentration: > 100000 nM
Compound 3 ended at the assay's limit (the forecaster's own chance of this, stated with the estimate: 70%); the middle value lies on the limit itself.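

The steps from compound 1 and from compound 2 to compound 3 cannot be read, and one shared result is all that stands: the limit of > 100000 nM in this assay, at which 3 of the 3 values shown sit. The compounds shown leave open which change on the shared core, if any, would give a readable value in this assay.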